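The source may report more compounds than this note shows. Statements on the series, on what has been measured and on what is new or still open speak of the compounds shown alone.

In an assay on isolated protein for inhibition of lysosomal alpha-glucosidase (Rattus norvegicus), read by colorimetric assay (on this read-out lower numbers stand for stronger inhibition and higher numbers for weaker inhibition), compound 1 `OC[C@]1(c2ccc(F)cc2)NC[C@H](O)[C@H]1O` gives 101000 nM, the higher of the two numbers recorded so far; compound 2 `CCCC[C@@]1(CO)NC[C@H](O)[C@H]1O` gives 220 nM, a lower number by a margin beyond the usual scatter. Compound 3 `Cc1ccc([C@@]2(CO)NC[C@H](O)[C@H]2O)cc1` has not yet been measured in this assay. It differs from compound 1 by methyl in place of fluoro on an aromatic carbon, the exchange taking place on the six-membered aromatic ring of carbon only, para to a group of 9 heavy atoms. Within the data shown here, no measured pair shows the effect of this exchange, so its size is unknown from the data. Since one heavy atom leaves and one heavy atom enters, with no change in ring count, donors, acceptors or charge, the expected step from compound 1 to compound 3 is a 1.1-fold lower number from compound 1 to compound 3 (0.05 log units; within the scatter), which is not beyond the scatter. Compound 3 is therefore estimated at 90000 nM, with a range from 30000 nM to 270000 nM.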

Compound 3, half-maximal inhibitory concentration: 17000 nM
Estimate against measurement, compound 3: 5.3-fold (0.72 log units) above, and the stated range ends above it.
By their numbers in this assay, from the lowest: compound 2; then compound 3; then compound 1.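

In this assay, placing methyl instead of fluoro on the aromatic carbon gives a 5.9-fold lower number from compound 1 to compound 3 (0.77 log units; beyond the scatter). Among these compounds, this shows that the number responds to a change at this position, which the earlier compounds did not test, although one heavy atom simply replaces another and the counts of rings, donors and acceptors and the net charge stay the same. Nothing available accounts for the difference between the methyl and fluoro compounds.

The compounds shown leave open whether a chloro, methoxy or trifluoromethyl group in the same place would move the number further in the same direction, or whether an amine or a carboxylic acid would reverse it. They also leave open whether the same exchange would give a step of similar size at another carbon of the ring.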